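A few compounds are considered here, and "the series" means these few. Any claim that something is new, unique, unknown or untested is made for them only; others in the source may bear on it.

Measured so far:
compound 1 `CC(C(=O)NCc1ccc(C(C)(C)C)nc1N1CCC(Cc2ccccc2)CC1)c1ccc(NS(C)(=O)=O)c(F)c1`: 0.3 nM
compound 2 `CCCCOc1nc(C(C)(C)C)ccc1CNC(=O)C(C)c1ccc(NS(C)(=O)=O)c(F)c1`: 0.9 nM
compound 3 `CC(C)Oc1nc(C(C)(C)C)ccc1CNC(=O)C(C)c1ccc(NS(C)(=O)=O)c(F)c1`: 2.3 nM

All three were run in an assay on cells for antagonist activity at transient receptor potential cation channel subfamily V member 1 (Homo sapiens), read by FLIPR and calcium flux, with a stated time of 6 min; a lower number here means a stronger inhibitor, a higher number a weaker inhibitor. Compound 3 gives the highest number of the three; its nearest neighbour is compound 2, and compound 1 lies furthest from it. For the measured compounds named here, the only single-point step within the measured set is a 2.6-fold higher number from compound 2 to compound 3 (0.41 log units; beyond the scatter), a modest move.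

Compound 4 `CCCCSc1nc(C(C)(C)C)ccc1CNC(=O)C(C)c1ccc(NS(C)(=O)=O)c(F)c1` has not yet been measured. Against compound 3 the change is butylsulfanyl in place of isopropoxy on an aromatic carbon. Going by the values given here, only the step from compound 2 to compound 3 bears on this: it covers the butyl-to-isopropyl part of the change on an oxygen, and compound 4 reverses that part while also putting sulfur where oxygen stood. Among the compounds with values here, no measured pair says anything about oxygen against sulfur at that place. Taking compound 2 as the closest analogue, a return toward its number is expected, with the sulfur part left as the open uncertainty.

Compound 4 is expected at 1 nM (range 0.4 nM to 3 nM), meaning an expected step of a 2.3-fold lower number from compound 3 to compound 4 (0.36 log units; beyond the scatter).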

Compound 4, inhibition constant: 3.2 nM
For compound 4 the middle estimate is 3.2-fold (0.51 log units) below the measured one, and the stated range ends below it.
By their numbers in this assay, from the lowest: compound 1; then compound 2; then compounds 3 and 4 (each within the scatter of the next).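

In this assay, for the compounds shown here, butylsulfanyl in place of butoxy on this aromatic carbon gives a 3.6-fold higher number from compound 2 to compound 4 (0.55 log units; beyond the scatter) as a first direct reading of sulfur against oxygen here, with the butyl chain held constant. Butylsulfanyl in place of isopropoxy gives a 1.4-fold higher number from compound 3 to compound 4 (0.14 log units; within the scatter) and so leaves compound 3 and compound 4 without a readable difference, although butoxy in compound 2 stands apart from isopropoxy in compound 3 by a 2.6-fold higher number from compound 2 to compound 3 (0.41 log units; beyond the scatter) in the same assay. No measurement shown explains the sulfur step.

Open, from the compounds shown here alone, is how isopropylsulfanyl would read against isopropoxy, which would show whether the sulfur step holds with a different chain. Also open, going by these compounds, is how a longer chain on sulfur, or a simple amine on this carbon, would compare with compound 1 at 0.3 nM in this assay.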